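Carbamoyl for methoxy on the silicon-bound aryl

The source may report more compounds than this note shows. Statements on the series, on what has been measured and on what is new or still open speak of the compounds shown alone.

Compound 1 `CCN(C/C=C/C#CC(C)(C)C)Cc1cccc(OC[Si](C)(C)c2ccc(OC)cc2)c1` gives 870 nM in a functional assay on liver (Sus scrofa) for inhibition of squalene monooxygenase (Homo sapiens), using microsomes (on this read-out lower numbers stand for stronger inhibition and higher numbers for weaker inhibition), the highest of the two numbers to hand; compound 2 `CCN(C/C=C/C#CC(C)(C)C)Cc1cccc(OC[Si](C)(C)c2ccccc2C(F)(F)F)c1` gives 70 nM. The step of a 12-fold lower number from compound 1 to compound 2 (1.09 log units; beyond the scatter) is the only measured one, and it exchanges a different group on that ring, so it offers no direct guide. Compound 3 `CCN(C/C=C/C#CC(C)(C)C)Cc1cccc(OC[Si](C)(C)c2ccc(C(N)=O)cc2)c1` carries carbamoyl in place of methoxy on an aromatic carbon. Without a comparable step, no change beyond the scatter is expected, though the range is kept wide given how far a single exchange on this ring moved the number in a 12-fold lower number from compound 1 to compound 2 (1.09 log units; beyond the scatter). For compound 3 the estimate is 1000 nM, range 250 nM to 4000 nM, a step of a 1.1-fold higher number from compound 1 to compound 3 (0.06 log units; within the scatter).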

Compound 3, half-maximal inhibitory concentration: 5000 nM
Beside the measured number, compound 3's estimate is 5.0-fold (0.70 log units) below it, and the stated range ends below it.
By their numbers in this assay, from the lowest: compound 2; then compound 1; then compound 3.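

In this assay, carbamoyl in place of methoxy on an aromatic carbon, para to a large group, gives a 5.7-fold higher number from compound 1 to compound 3 (0.76 log units; beyond the scatter), so this place on the ring can also move the number upward. Against the 2-(trifluoromethyl)phenyl group the gap is wider, with a 71-fold higher number from compound 2 to compound 3 (1.85 log units; beyond the scatter), and the aryl group on silicon spans a broad range across these three compounds. No measurement at hand accounts for either step.

Going by these compounds, whether a nitrile, a carboxylic acid or a plain phenyl ring would read closer to methoxy or to carbamoyl stays open.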